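Amino-substituted quinoxaline growth inhibitors on SK-MEL-28 cells

The source may report more compounds than this note shows. Statements on the series, on what has been measured and on what is new or still open speak of the compounds shown alone.

Measured compounds:
compound 1, `Nc1cc(N)c2nc(-c3ccccc3)c(Oc3ccc(Cl)c(Cl)c3)nc2c1`, 21400 nM
compound 2, `CCOC(=O)[C@H](CCC(=O)O)NC(=O)c1ccc(CNc2nc3cc(N)cc(N)c3nc2-c2ccccc2)cc1`, 26900 nM
compound 3, `Nc1cc(N)c2nc(-c3ccccc3)c(NCc3ccc(Cl)c(Cl)c3)nc2c1`, 18600 nM

Of the compounds shown here, three sharing one core have been tested in a functional assay on SK-MEL-28 cells (Homo sapiens) for inhibition, read by sulforhodamine B assay, with a stated time of 48 h; a lower number here means a stronger inhibitor of growth, a higher number a weaker inhibitor of growth. Compound 1 gives 21400 nM, compound 2 gives 26900 nM, and compound 3 gives 18600 nM. Compound 3 has the lowest of the three numbers, but compound 1 and compound 2 both lie within the scatter of it, so no order among the three can be read from these data; all three sit in the same weak range.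

The next compound, compound 4, `COc1ccc(CNc2nc3cc(N)cc(N)c3nc2-c2ccccc2)cc1OC`, has not yet been measured. It differs from compound 3 in one place: 3,4-dimethoxyphenyl in place of 3,4-dichlorophenyl on a saturated chain carbon bound to a nitrogen on an aromatic ring. Among the measured compounds shown here, no pair among the measured compounds differs in one place, so the data give no step that would show what such an exchange does in this assay. What can be said is that three different groups on the shared core all gave numbers within the scatter of one another.

On that basis the expectation for compound 4 in this assay is a step from compound 3 of about a 1.3-fold higher number from compound 3 to compound 4 (0.13 log units; within the scatter), that is, none beyond the scatter. Compound 4 is therefore estimated at 25000 nM, with a range from 10000 nM to 60000 nM.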

Compound 4, concentration for 50% growth inhibition: 13500 nM
Beside the measured number, compound 4's estimate is 1.9-fold (0.27 log units) above it, within the range that was stated.
By their numbers in this assay, from the lowest: compounds 4, 3, 1 and 2 (each within the scatter of the next).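

In this assay, putting 3,4-dimethoxyphenyl in place of 3,4-dichlorophenyl on a saturated chain carbon bound to a nitrogen on an aromatic ring gives a 1.4-fold lower number from compound 3 to compound 4 (0.14 log units; within the scatter). Among the compounds shown here, this is the first exchange in the set that can be read at a single place, and it shows that these two groups cannot be told apart at this position, although the entering group counts 2 hydrogen-bond acceptors and the leaving group 0. The result therefore offers no sign that this exchange matters for growth inhibition in these cells, and no measurement at hand accounts for it.

The compounds shown leave open whether any group at this position can move the number beyond the scatter, since this single exchange tests only one pair of substituted phenyl groups. An amine or a carboxylic acid in place of the methoxy groups, or a longer chain in place of the single saturated carbon, could each be tested against compound 4 in this assay to answer that.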